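The compounds below may be only part of what the source reports. "The series", "measured", "known", "first", "only" and "open" are said of these compounds alone.

Measured in a functional assay on PC-3 cells (Homo sapiens) for inhibition; a higher number here means a weaker inhibitor of growth, a lower number a stronger inhibitor of growth:
- compound 1 `O=C(O)c1nc(-c2cccc(F)c2)[nH]c1C(=O)O`: "not determined" (no result reported)
- compound 2 `CCNC(=O)c1nc(-c2ccccc2)[nH]c1C(=O)O`: "not determined" (no result reported)
- compound 3 `CCOC(=O)CN(Cc1ccccc1)C(=O)c1nc(-c2ccccc2)[nH]c1C(=O)O`: > 200000 nM

Compound 2 offers no number to start from. In this assay compound 2 stands at "not determined" (no result reported), and so no position can be given for it among the three compounds. Compound 1 gives no number either, at "not determined" (no result reported). Among the measured compounds shown here, compound 3 is the only one with a reading, and that reading, > 200000 nM, is a limit and not a number.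

The step followed here leads to compound 4 `CN(CC(N)=O)C(=O)c1nc(-c2ccccc2)[nH]c1C(=O)O`, which has yet to be measured. The change is (carbamoylmethyl)(methyl)amino in place of ethylamino on a carbonyl carbon: (carbamoylmethyl)(methyl)amino stands in place of ethylamino on a carbonyl carbon, while the rest of the structure stays as it is. For the measured compounds named here, no measured step shows what such a change does in this assay. Going by the values given here, the only guide is compound 3, with the limit of > 200000 nM in this assay, at which 1 of the 3 values shown sits. On that basis, the change is expected to bring no step beyond the scatter, in either direction, and compound 4 is expected to remain a weak inhibitor of growth, quite possibly reported only as a limit. The estimated value for compound 4 is 200000 nM, with an expected range from 80000 nM to 400000 nM.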

Compound 4, concentration for 50% growth inhibition: > 200000 nM
Compound 4 gave a limit, no number; the forecaster's own chance of this, stated with the estimate: 75%; the middle value sits exactly at the limit.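

In this assay compound 4 gives > 200000 nM, which is a limit and not a number. Among the compounds shown here, compound 2 offers no number to compare with it, so no step from compound 2 to compound 4 can be read. The compounds shown leave open how any change on the carbonyl carbon affects growth inhibition in this assay.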